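A few compounds are considered here, and "the series" means these few. Any claim that something is new, unique, unknown or untested is made for them only; others in the source may bear on it.

Compound 2 `COc1cc2cc(Oc3ccc(NC(=O)Nc4ccc(C)cc4)cc3)c(C)nc2cc1OC` gives 130% in a functional assay on BT-549 cells (Homo sapiens) for inhibition, read by sulforhodamine B assay, with a stated time of 48 h, tested at 10 uM (on this read-out higher numbers stand for a weaker effect at the one concentration tested and lower numbers for a stronger effect), the higher of the two numbers recorded, standing above compound 1 `COc1cc2cc(Oc3ccc(NC(=O)Nc4ccccc4)cc3)c(C)nc2cc1OC`, which gives 104% in this assay. Going by the values given here, the only measured step, a number 26 percentage points higher from compound 1 to compound 2 (beyond the scatter), concerns the methyl that compound 3 `COc1cc2cc(Oc3ccc(NC(=O)Nc4ccc(C(F)(F)F)cc4)cc3)c(C)nc2cc1OC` now replaces: trifluoromethyl in place of methyl on an aromatic carbon. Among the compounds with values here, no measured step exchanges methyl for trifluoromethyl, so the expectation leans on that single modest step and on the scatter, and no shift beyond the scatter is expected in this assay. Compound 3 is expected to give 122%, between 98% and 146%, an estimated step of a number 8 percentage points lower from compound 2 to compound 3 (within the scatter).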

Compound 3, a percentage reported as activity, at one concentration (the size of the read-out at that concentration, not a potency): 113%
For compound 3 the middle estimate is 9 percentage points above the measured one; the measured number falls inside the stated range.
By their numbers in this assay, from the lowest: compounds 1 and 3 (each within the scatter of the next); then compound 2.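

In this assay, the aromatic carbon para to a large group proves sensitive to which substituent it carries: trifluoromethyl in place of methyl gives a number 17 percentage points lower from compound 2 to compound 3 (beyond the scatter). Trifluoromethyl in place of hydrogen gives a number 9 percentage points higher from compound 1 to compound 3 (within the scatter), so unlike methyl, this group does not separate from hydrogen at this position. Nothing available accounts for the difference between the two groups. The compounds shown leave open how a methoxy group, a chlorine or an amine on this carbon would read, and whether methyl and trifluoromethyl would differ in the same way elsewhere on this ring.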